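The compounds below may be only part of what the source reports. "The series", "measured", "known", "first", "only" and "open" are said of these compounds alone.

Of the compounds shown here, three sharing one core have been tested in a functional assay on IMR-32 cells (Homo sapiens) for inhibition, read by sulforhodamine B assay, with a stated time of 48 h; on this read-out lower numbers stand for stronger inhibition and higher numbers for weaker inhibition. Compound 1 `Cc1ccc2occ(C3N=C(c4ccccc4)SS3)c(=O)c2c1` gives 70700 nM. Compound 2 `O=c1c(C(=S)Nc2ccccc2)coc2cc(Cl)ccc12` gives 92700 nM, and compound 3 `O=c1c(C2N=C(c3ccccc3)SS2)coc2cc(Cl)c(Cl)cc12` gives 58000 nM. Compound 1 stands second highest of the three numbers, but its gap to compound 3 and its gap to compound 2 both lie within the scatter, so the three values cannot be told apart. Compound 4 `O=c1c(C2N=C(c3ccccc3)SS2)coc2ccc(F)cc12` awaits measurement. It differs from compound 1 in one place: fluoro in place of methyl on an aromatic carbon. Going by the values given here, no pair of measured compounds shows this change, so nothing measured speaks for its size. In this assay the step from compound 1 to compound 4 is expected to be a 1.1-fold lower number from compound 1 to compound 4 (0.04 log units; within the scatter), meaning none beyond the scatter. Compound 4 is estimated at 65000 nM, within 30000 nM to 140000 nM.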

Compound 4, half-maximal inhibitory concentration: 14600 nM
For compound 4 the middle estimate is 4.5-fold (0.65 log units) above the measured one; the measured number lies below the stated range.
By their numbers in this assay, from the lowest: compound 4; then compounds 3, 1 and 2 (each within the scatter of the next).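

The step of a 4.8-fold lower number from compound 1 to compound 4 (0.69 log units; beyond the scatter) when fluoro takes the place of methyl on this aromatic carbon shows that this position can change the number beyond the scatter, though the step is modest. The earlier compounds shown here included no pair differing in one place, so they could not show this. No evidence is available to explain the step. The compounds shown include none with a methoxy or an amine at this carbon. On these data alone, whether other groups here would lower the number further, or raise it, remains open.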